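A ring swap repeated on a second core

The source may report more compounds than this note shows. Statements on the series, on what has been measured and on what is new or still open speak of the compounds shown alone.

Compound 1, `Cc1ccnc(/C(N)=N/NC(=S)N2CCOCC2)c1`, in a functional assay on A-431 cells (Homo sapiens) for cytotoxicity, read by MTT assay, with a stated time of 72 h, tested at 10 uM (on this read-out higher numbers stand for more inhibition of growth at the one concentration tested and lower numbers for less inhibition of growth), compound 1 gives 62%.
Compound 2, `Cc1ccnc(/C(N)=N/NC(=S)N2CCSCC2)c1`, in this assay compound 2 gives 60%.
Compound 3, `N/C(=N\NC(=S)N1CCSCC1)c1ccc(F)cn1`, in this assay compound 3 gives 61.8%.

The three measured compounds sit close together in this assay. Between compound 2 and compound 1 the only change is morpholin-4-yl in place of thiomorpholin-4-yl on a thiocarbonyl carbon, and this brings a number 2 percentage points higher from compound 2 to compound 1 (within the scatter). Compound 3 carries the same thiomorpholin-4-yl group as compound 2 on a different core; the difference between the two cores is not broken down here, and the two values show nothing that the scatter would not cover.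

Compound 4, `N/C(=N\NC(=S)N1CCOCC1)c1ccc(F)cn1`, is not yet measured. It differs from compound 3 by morpholin-4-yl in place of thiomorpholin-4-yl on a thiocarbonyl carbon, the same change that was made from compound 2 to compound 1. Because that earlier step was a number 2 percentage points higher from compound 2 to compound 1 (within the scatter), compound 4 is expected to move from compound 3 by about a number 1.2 percentage points higher from compound 3 to compound 4 (within the scatter) in this assay. For compound 4 the estimated value is 63%, expected to fall between 53% and 73%.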

Compound 4, percent growth inhibition at one concentration: 66.9%
Beside the measured number, compound 4's estimate is 3.9 percentage points below it, within the range that was stated.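

In this assay, morpholin-4-yl in place of thiomorpholin-4-yl on a thiocarbonyl carbon brings a number 5.1 percentage points higher from compound 3 to compound 4 (within the scatter). Set beside the same swap on the core of compound 1, the new step does not differ from the earlier one: the same change on two cores in this assay, a number 2 percentage points higher (within the scatter) from compound 2 to compound 1 and a number 5.1 percentage points higher (within the scatter) from compound 3 to compound 4, 3.1 percentage points apart, within the scatter of two such steps

On these two cores, then, the swap reads alike, but each step lies within the scatter, so the pair shows no clear effect of the swap on either core, and two cores cannot show how it would behave on a third.

The compounds shown leave open how this assay would read with a piperazin-1-yl ring or an open-chain dimethylamino group on the thiocarbonyl carbon in place of these two rings. They also leave open whether the close agreement would hold across a range of concentrations or on other cell lines, as every value here comes from one concentration on one cell line.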